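Replacing trifluoromethyl with nitro on compound 2

The compounds below may be only part of what the source reports. "The series", "measured", "known", "first", "only" and "open" are said of these compounds alone.

In an ADME assay on MDBK cells (Bos taurus) for cytotoxicity, read by MTT assay, with a stated time of 96 h (a lower number here means that less compound is tolerated, a higher number that more compound is tolerated), compound 1 (`O=[N+]([O-])c1ccccc1-c1nc2ccccc2[nH]1`) gives > 100000 nM as a limit of the assay, not a number. Compound 2 (`COc1ccc(-c2nc3cc(C(F)(F)F)ccc3[nH]2)c(OC)c1OC`) gives > 100000 nM as a limit too. Its place is therefore the limit of > 100000 nM in this assay, at which 2 of the 3 values shown sit, and no exact number is known for it. Compound 3 (`COc1cc(-c2nc3cc(C(F)(F)F)ccc3[nH]2)cc(OC)c1OC`) gives 18000 nM as a true number.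

Compound 4 (`COc1ccc(-c2nc3cc([N+](=O)[O-])ccc3[nH]2)c(OC)c1OC`) is compound 2 with nitro in place of trifluoromethyl on an aromatic carbon. Going by the values given here, no measured pair shows this exact change, so any forecast is tentative. Compound 1 also carries a nitro group and gives > 100000 nM as a limit, which argues against expecting a large change. Compound 3 at 18000 nM keeps a lower reading possible. The expected move is an at least 1.4-fold lower number from compound 2 to compound 4 (0.15 log units; that floor lies within the scatter) in the direction of less compound tolerated, a small one and perhaps none beyond the scatter. For compound 4 the estimated value is 70000 nM with an expected range from 20000 nM to 100000 nM and the assay may again report only a limit.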

Compound 4, half-maximal cytotoxic concentration: > 100000 nM
Compound 4 ended at the assay's limit; the forecaster's own chance of this, stated with the estimate: 50%; middle value at least 1.4-fold (0.15 log units) from the limit.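

Compound 2 and compound 4 each give only a limit of the assay and not a number, so no step between them can be read: the limit of > 100000 nM in this assay, at which 3 of the 4 values shown sit.

The compounds shown leave open how far nitro in place of trifluoromethyl on an aromatic carbon moves the reading in this assay.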